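Replacing methyl(phenyl)amino with benzylsulfanyl: notes on compound 3

The compounds below may be only part of what the source reports. "The series", "measured", "known", "first", "only" and "open" are said of these compounds alone.

Measured in a functional assay (brain) with Canis familiaris (Canis lupus familiaris) as the target; a lower number here means a stronger inhibitor, a higher number a weaker inhibitor:
Compound 1 `CC(=O)N(CC(O)CN1CCN(CCCC(c2ccc(F)cc2)c2ccc(F)cc2)CC1)c1ccccc1` gives 390000 nM
Compound 2 `CN(CC(O)CN1CCN(CCCC(c2ccc(F)cc2)c2ccc(F)cc2)CC1)c1ccccc1` gives 19000 nM

Compound 2 holds the lower of the two numbers (19000 nM). Compound 3 `OC(CSCc1ccccc1)CN1CCN(CCCC(c2ccc(F)cc2)c2ccc(F)cc2)CC1` carries benzylsulfanyl in place of methyl(phenyl)amino on a saturated chain carbon (benzylsulfanyl in place of methyl(phenyl)amino on a saturated chain carbon, two bonds along the chain from an oxygen on a saturated carbon). For the measured compounds named here, the only measured step (a 21-fold lower number from compound 1 to compound 2 (1.31 log units; beyond the scatter)) is large, but it concerns methyl in place of acetyl on a nitrogen on an aromatic ring. Going by the values given here, no measured step covers this swap, so it gives no direction, though the wide range allows for a large move. No step beyond the scatter is expected in this assay (estimated: a 1.3-fold lower number from compound 2 to compound 3 (0.10 log units; within the scatter)). For compound 3 the expected value is 15000 nM (estimated range 4000 nM to 60000 nM).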

Compound 3, half-maximal inhibitory concentration: 28000 nM
Compound 3: middle estimate off by 1.9-fold (0.27 log units), on the low side; the range from low to high includes it.
By their numbers in this assay, from the lowest: compounds 2 and 3 (each within the scatter of the next); then compound 1.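

In this assay the step of a 1.5-fold higher number from compound 2 to compound 3 (0.17 log units; within the scatter) shows that, on this saturated chain carbon, benzylsulfanyl and methyl(phenyl)amino cannot be told apart, so a nitrogen on the aromatic ring is not needed here. The step of a 14-fold lower number from compound 1 to compound 3 (1.14 log units; beyond the scatter) shows that benzylsulfanyl keeps the large gap to acetyl(phenyl)amino first seen with methyl(phenyl)amino, leaving the acetyl compound the outlier of the three. As far as these compounds go, whether the aromatic ring of benzylsulfanyl matters remains open, as does the length of its chain, which cyclohexylmethylsulfanyl and phenethylsulfanyl would address. No evidence bears on the reason for these readings.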